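Compound 3 to compound 4: change on the amide-type nitrogen

The source may report more compounds than this note shows. Statements on the series, on what has been measured and on what is new or still open speak of the compounds shown alone.

In a physicochemical assay for solubility (on this read-out higher numbers stand for higher solubility and lower numbers for lower solubility), compound 3 (`CNC(=O)c1cc(C(=O)Nc2cnn(C)c2)cc2c1OC[C@H]2c1ccccc1`) reads >= 189 ug/mL and this is a limit, not a number. Compound 1 (`CNC(=O)c1cc(C(=O)N[C@H]2[C@@H]3C[C@@H](O)C[C@@H]32)cc2c1OC[C@H]2c1ccccc1`) reads >= 124 ug/mL and this too is a limit. Compound 2 (`CNC(=O)c1cc(C(=O)N[C@H]2[C@@H]3COC[C@@H]32)cc2c1OC[C@@]2(C)c1ccccc1`) reads >= 147 ug/mL and this too is a limit. No firm rank for compound 3 can be taken from these three readings.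

The next structure is compound 4 (`CNC(=O)c1cc(C(=O)N[C@H]2C[C@@H]2C)cc2c1OC[C@H]2c1ccccc1`), which carries 2-methylcyclopropyl in place of 1-methyl-1H-pyrazol-4-yl on an amide-type nitrogen. Going by the values given here, one measured step bears on this change, as it also swaps the group on that nitrogen (a step that the two limits leave unreadable from compound 1 to compound 3). Its size cannot be read, so it offers no measured size and no direction to carry over. Nothing in the data points to a shift, so no step beyond the scatter is expected in this assay, and this expectation rests on that one unreadable step alone. The expected step (an at least 1.1-fold lower number from compound 3 to compound 4 (0.04 log units; that floor lies within the scatter)) is an estimate with no firm direction. The reading is expected to be a limit again. For compound 4 the estimated value is 170 ug/mL with an expected range from 90 ug/mL to 300 ug/mL in this read-out.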

Compound 4, solubility: >= 76 ug/mL
Compound 4 was reported as a limit (the forecaster's own chance of this, stated with the estimate: 75%); the middle value lies beyond the limit too.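

In this assay compound 4 gives >= 76 ug/mL, which is a limit. Going by these compounds alone, the readings of compound 1 and compound 3 are limits too, and no step from either of them to compound 4 can be read. The compounds shown leave open whether the group on the amide-type nitrogen shifts the reading in this assay at all, and in which direction.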